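Tert-butyl for ethyl on the chain carbon of compound 3

A few compounds are considered here, and "the series" means these few. Any claim that something is new, unique, unknown or untested is made for them only; others in the source may bear on it.

Three compounds share one core and differ only in the aromatic ring attached to a saturated chain carbon. Compound 1 `CC[C@@H](Nc1c(Nc2cccc(C(=O)N(C)C)c2O)c(=O)c1=O)c1cc(C)cs1` gives 24 nM in an assay on CHO cells for displacement of a labelled ligand from C-X-C chemokine receptor type 1 (Homo sapiens); on this read-out lower numbers stand for stronger inhibition and higher numbers for weaker inhibition. Compound 2 `CC[C@@H](Nc1c(Nc2cccc(C(=O)N(C)C)c2O)c(=O)c1=O)c1sccc1C` gives 123 nM, a step of a 5.1-fold higher number from compound 1 to compound 2 (0.71 log units; beyond the scatter). Compound 3 `CC[C@@H](Nc1c(Nc2cccc(C(=O)N(C)C)c2O)c(=O)c1=O)c1cc(C(C)C)co1` gives 3 nM, the lowest of the three; the steps were an 8.0-fold lower number from compound 1 to compound 3 (0.90 log units; beyond the scatter) and a 41-fold lower number from compound 2 to compound 3 (1.61 log units; beyond the scatter).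

Compound 4 `CC(C)c1coc([C@H](Nc2c(Nc3cccc(C(=O)N(C)C)c3O)c(=O)c2=O)C(C)(C)C)c1` keeps the ring of compound 3 and changes the chain instead: tert-butyl in place of ethyl on a saturated chain carbon bound to an aromatic carbon and a nitrogen on an aromatic ring. Among the measured compounds shown here, none of the measured steps touches this part of the molecule, so no measured step bears directly on it. Without a comparable step, the expectation for compound 4 rests on compound 3 alone and allows for a shift in either direction, most likely of modest size. The expected outcome is a step of a 2.0-fold higher number from compound 3 to compound 4 (0.30 log units; within the scatter), with compound 4 estimated at 6 nM, within a range from 1.5 nM to 25 nM.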

Compound 4, inhibition constant: 14 nM
Compound 4: the middle estimate sits 2.3-fold (0.37 log units) below what was measured, and the stated range covers the measured number.
By their numbers in this assay, from the lowest: compound 3; then compounds 4 and 1 (each within the scatter of the next); then compound 2.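

Among the compounds shown here, this is the first change at the chain carbon rather than on the aromatic ring, and swapping ethyl for tert-butyl gives a 4.7-fold higher number from compound 3 to compound 4 (0.67 log units; beyond the scatter) in this assay. The position therefore responds to what sits on it, yet it tolerates the larger group, since the shift is smaller than a 41-fold lower number from compound 2 to compound 3 (1.61 log units; beyond the scatter) produced by changing the ring. Nothing available explains why the number rose.

With only ethyl and tert-butyl compared at this carbon, two groups cannot define a trend, and a propyl chain, a cyclopropyl ring or a chain carrying an amine could fall anywhere relative to them. On these data alone, it also remains open whether tert-butyl would bring a similar step when paired with the 4-methylthiophen-2-yl ring of compound 1 instead of the 4-isopropylfuran-2-yl ring.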